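The source may hold more compounds than are shown below. What is called first, only, known or untested is meant among the compounds shown, and "the series" means these compounds.

Of the compounds shown here, three sharing one core have been measured in a functional assay on HL-60 cells (Homo sapiens) for inhibition, read by resazurin assay, with a stated time of 72 h; on this read-out higher numbers stand for weaker inhibition and lower numbers for stronger inhibition. There, compound 3 `CCOc1ccc(C2C(Oc3ccccc3)C(=O)N2c2cc(OC)c(OC)c(OC)c2)cc1` gives 494 nM, level within the scatter with compound 1 `C=CC1C(=O)N(c2cc(OC)c(OC)c(OC)c2)C1c1ccc(SCC)cc1` at 320 nM. Compound 2 `C=CC1C(=O)N(c2cc(OC)c(OC)c(OC)c2)C1c1ccc(OC)cc1` gives a lower number, 33 nM.

The next compound, compound 4 `C=CC1C(=O)N(c2cc(OC)c(OC)c(OC)c2)C1c1ccc(OCC)cc1`, keeps the 4-ethoxyphenyl group of compound 3 but carries vinyl in place of phenoxy on a saturated ring carbon. Within the data shown here, no measured step covers this exchange directly, and compound 3 is the only phenoxy compound at hand. The nearest evidence comes from the two measured vinyl compounds. Between them lies a 9.7-fold lower number from compound 1 to compound 2 (0.99 log units; beyond the scatter), with methoxy in place of ethylsulfanyl on an aromatic carbon, a step beyond the scatter. Compound 4 shares the vinyl group with both, so its number is expected to fall within their span. Its ethoxy group, attached through oxygen, resembles the methoxy of compound 2 at 33 nM more than the ethylsulfanyl of compound 1 at 320 nM, which points to the lower part of that span.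

A drop beyond the scatter is therefore expected, a 7.1-fold lower number from compound 3 to compound 4 (0.85 log units; beyond the scatter). The estimated value for compound 4 is 70 nM, within an expected range of 20 nM to 250 nM.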

Compound 4, half-maximal inhibitory concentration: 35 nM
Compound 4: middle estimate off by 2.0-fold (0.30 log units), on the high side; measured number inside the range.
By their numbers in this assay, from the lowest: compounds 2 and 4 (each within the scatter of the next); then compounds 1 and 3 (each within the scatter of the next).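

In this assay, putting vinyl in place of phenoxy on the saturated ring carbon, with the 4-ethoxyphenyl group kept, gives a 14-fold lower number from compound 3 to compound 4 (1.15 log units; beyond the scatter) for this exchange, so the group on this ring carbon alone can move the number beyond the scatter. With vinyl held fixed, the methyl added to the methoxy chain gives a 1.1-fold higher number from compound 2 to compound 4 (0.03 log units; within the scatter) and leaves the number within the scatter, whereas ethoxy in place of ethylsulfanyl gives a 9.1-fold lower number from compound 1 to compound 4 (0.96 log units; beyond the scatter) with the ethyl chain unchanged, which places the earlier difference on the linking atom, oxygen against sulfur, rather than on the length of the chain. Nothing at hand explains why either exchange has the effect it has.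

The compounds shown leave open whether vinyl itself matters on this ring carbon or whether an ethyl group, a hydroxy group or an amine there would give a similar number. They also leave open whether a longer chain on the oxygen, such as propoxy, would stay within the scatter of methoxy and ethoxy.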